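From benzyl to tert-butyl on an amide nitrogen

The source may report more compounds than this note shows. Statements on the series, on what has been measured and on what is new or still open speak of the compounds shown alone.

- compound 1 `CCCC(=O)OCSc1ccccc1C(=O)N[C@H]1CCC[C@H]1C(N)=O`: 89.9 uM; 84.8 uM (2 entries)
- compound 2 `CCCC(=O)OCSc1ccccc1C(=O)NCC(=O)NC`: > 100 uM (a limit of the assay, not a number)
- compound 3 `CCCC(=O)OCSc1ccccc1C(=O)NCC(=O)NCc1ccccc1`: 29.3 uM

Among the measured compounds shown here, in an ADME assay on CEM-SS cells (Homo sapiens) for cytotoxicity, read by XTT assay, with a stated time of 6 days (on this read-out higher numbers stand for lower toxicity in this test and lower numbers for higher toxicity in this test), compound 3, at 29.3 uM, is the only compound with one plain number. Compound 1 has two entries and compound 2 has a limit. Compound 4 `CCCC(=O)OCSc1ccccc1C(=O)NCC(=O)NC(C)(C)C` carries tert-butyl in place of benzyl on an amide-type nitrogen. For the measured compounds named here, the one measured step that bears on this is an at least 3.4-fold lower number from compound 2 to compound 3 (0.53 log units; beyond the scatter), which lies beyond the scatter and brought in the phenyl that compound 4 lacks. A partial return toward higher numbers, meaning lower toxicity, is therefore expected, an estimated 2.0-fold higher number from compound 3 to compound 4 (0.31 log units; beyond the scatter). The estimate for compound 4 is 60 uM, with an expected range of 28 uM to 110 uM.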

Compound 4, half-maximal toxic concentration: 46.8 uM
Estimate against measurement, compound 4: 1.3-fold (0.11 log units) above; low and high end bracket the measured number.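

In this assay, the change from benzyl to tert-butyl gives a 1.6-fold higher number from compound 3 to compound 4 (0.20 log units; within the scatter), so on this amide-type nitrogen these two groups cannot be told apart, although only benzyl carries a ring. Tert-butyl in place of methyl gives an at least 2.1-fold lower number from compound 2 to compound 4 (0.32 log units; beyond the scatter), so the drop seen with compound 3 does not require a phenyl ring. Compound 2 holds a limit of the assay, not a number: the limit of > 100 uM in this assay, at which 1 of the 4 values shown sits.

The compounds shown leave open how a longer chain such as n-butyl would read on this nitrogen. On these data alone, a group carrying a carboxylic acid or an amine remains equally open.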